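Losing the chloroacetate ester: compound 2 to compound 3

This account rests on a few compounds, and the source may have more. Where it says the series, first, only, none or still open, it means among the compounds named here.

Measured in a functional assay on A2780 cells (Homo sapiens) for cytotoxicity, read by sulforhodamine B assay, with a stated time of 96 h; a lower number here means that less compound is needed, a higher number that more compound is needed for the effect:
- compound 1 `CCCC(=O)CC/C=C/C=C/C#CC#C/C=C/COC(=O)c1ccccc1`: > 30000 nM, a limit of the assay
- compound 2 `CCCC(=O)CC/C=C/C=C/C#CC#C/C=C/COC(=O)CCl`: 3600 nM

Among the compounds with values here, compound 2 carries the only actual number so far, since the entry for compound 1 is a limit. The next structure is compound 3 `CCCC(=O)CC/C=C/C=C/C#CC#C/C=C/C(=O)O`, with the change (carboxy in place of (((chloromethyl)carbonyl)oxy)methyl on a double-bonded chain carbon bound to a double-bonded chain carbon). Within the data shown here, one measured step bears on it: an at least 8.3-fold lower number from compound 1 to compound 2 (0.92 log units; beyond the scatter). That step rests on (the limit of > 30000 nM in this assay, at which 1 of the 2 values shown sits), so its true size is not fixed. It altered the group on a carbonyl carbon, and the chloromethyl involved leaves entirely in compound 3. Compound 1, without chloromethyl, sits at a limit in this assay, so a step of similar size towards a higher number is expected, though this single comparison is thin support. The expected change is a 4.2-fold higher number from compound 2 to compound 3 (0.62 log units; beyond the scatter). For compound 3 the estimated value is 15000 nM, with an expected range of 5000 nM to 30000 nM.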

Compound 3, half-maximal effective concentration: > 30000 nM
Compound 3: a limit, no number; the forecaster's own chance of this, stated with the estimate: 45%; at least 2.0-fold (0.30 log units) between middle value and limit.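

Replacing (((chloromethyl)carbonyl)oxy)methyl with carboxy on this double-bonded chain carbon gives an at least 8.3-fold higher number from compound 2 to compound 3 (0.92 log units; beyond the scatter) in this assay. Compound 3 gives > 30000 nM, which is a limit of the assay and not a number. With compound 2 still the only one of the three compounds with a measured number, a second change at this end of the chain has now ended at the limit, and the size of the step stays unfixed: the limit of > 30000 nM in this assay, at which 2 of the 3 values shown sit.

The compounds shown leave open whether the chloromethyl alone or the whole ester accounts for the number of compound 2, as compound 3 removes both at once. A bromomethyl on the carbonyl carbon, or a simple hydroxymethyl in place of the ester, would separate these two readings.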